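A Bicyclic Replacement for the Nitrile Ring

The source may hold more compounds than are shown below. What is called first, only, known or untested is meant among the compounds shown, and "the series" means these compounds.

Compound 1 `N#Cc1ccc(Oc2cccc(NCc3cccc(OC(F)(F)F)c3)c2)cc1` is a diaryl ether: one ring carries a nitrile, the other carries an amine linked to a benzylic group bearing a trifluoromethoxy substituent. In a functional assay on PLC5 cells (Homo sapiens) for inhibition, read by MTT assay, with a stated time of 24 h (a lower number here means a stronger inhibitor, a higher number a weaker inhibitor), compound 1 gives only a limit, > 15000 nM, so no number is known for it. Compound 2 `N#Cc1ccc(Oc2cccc(NS(=O)(=O)c3ccccc3)c2)cc1` swaps the benzylic amine for a sulfonamide and also reaches only a limit in this assay, > 15000 nM. Among the compounds with values here, compound 3 `Nc1cc(Oc2cccc(NS(=O)(=O)c3cccc(C(F)(F)F)c3)c2)ccc1[N+](=O)[O-]` carries an amino-nitrophenyl ether and a trifluoromethyl-substituted sulfonamide, and in this assay compound 3 is the one compound with a measured number, 3900 nM. Compound 1 thus stands among the values that are only limits, because of the limit of > 15000 nM in this assay, at which 2 of the 3 values shown sit.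

Compound 4 `O=c1[nH]c2ccc(Oc3cccc(NCc4cccc(OC(F)(F)F)c4)c3)cc2[nH]1` differs from compound 1 by a group of 10 heavy atoms (7 carbon, 2 nitrogen, 1 oxygen; one five-membered aromatic ring with 2 hetero atoms, one six-membered aromatic ring of carbon only) in place of a group of 8 heavy atoms (7 carbon, 1 nitrogen; one six-membered aromatic ring of carbon only), on an oxygen on an aromatic ring. Within the data shown here, no pair of measured compounds differs in only one place, so nothing measured tells how large such a change should be, and the expectation rests on compound 1 alone. The step from compound 1 to compound 4 is expected to be modest, toward a stronger inhibitor, an at least 1.8-fold lower number from compound 1 to compound 4 (0.27 log units; that floor lies within the scatter). Compound 4 is expected to give about 8000 nM in this assay, in a range from 1500 nM to 30000 nM, with a fair chance that only a limit is reported once more.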

Compound 4, half-maximal inhibitory concentration: 10200 nM
Compound 4: middle estimate off by 1.3-fold (0.11 log units), on the low side; the measured number falls inside the stated range.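

The step from compound 1 to compound 4 is the first change shown at this position alone: the 4-cyanophenyl group on the oxygen gives way to a group of 10 heavy atoms, while the benzylic amine side stays the same. With this change, this assay yields a measured number rather than a limit, and the step reads as an at least 1.4-fold lower number from compound 1 to compound 4 (0.16 log units; that floor lies within the scatter). This is only a floor and not the true size of the change, because compound 1 has a limit and not a number: the limit of > 15000 nM in this assay, at which 2 of the 4 values shown sit.

The compounds shown leave open whether the change makes a real difference at all, and whether the same group would behave alike on the sulfonamide side of compound 2. They also leave open how much of the result depends on the whole entering group, which a carboxylic acid or a primary amide in place of the nitrile on the simple phenyl ring could begin to test.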